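Serine phosphodiester series: ring stereocentre inversion, compound 1 to 4

The source may report more compounds than this note shows. Statements on the series, on what has been measured and on what is new or still open speak of the compounds shown alone.

Measured compounds:
compound 1 `N[C@@H](COP(=O)(O)OC[C@H]1OCCC[C@H]1OC(=O)CCc1ccccc1OCc1cccc(Oc2ccccc2)c1)C(=O)O` — "not active" (no number reported)
compound 2 `CCCCCCCCCCCOc1ccccc1CCC(=O)OCc1ccccc1OP(=O)(O)OC[C@H](N)C(=O)O` — 0.02
compound 3 `Cc1ccc(Oc2cccc(COc3ccccc3CCC(=O)O[C@@H]3CCCO[C@@H]3COP(=O)(O)OC[C@H](N)C(=O)O)c2)cc1` — "not active" (no number reported)

The read-out throughout is an assay on HEK293-A cells with putative P2Y purinoceptor 10 (Mus musculus) as the target, with a stated time of 1.5 h; on this read-out higher numbers stand for larger maximal responses and lower numbers for smaller maximal responses. Compound 1 is reported there as "not active" (no number reported), with no number attached. Compound 3, which carries the same saturated ring and phosphodiester arrangement, is likewise reported as "not active" (no number reported). Only compound 2, the open-chain undecyloxy analogue, gives a number, and compound 2 gives 0.02, which sits at the very bottom of the scale. Compound 1 therefore stands among the compounds with nothing measurable, and no difference between any two of the three measured compounds can be read as beyond the scatter.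

Compound 4 `N[C@@H](COP(=O)(O)OC[C@H]1OCCC[C@@H]1OC(=O)CCc1ccccc1OCc1cccc(Oc2ccccc2)c1)C(=O)O` is the unmeasured entry. It differs from compound 1 only by the two compounds have the same atoms and bonds; at least one stereo element is drawn with a configuration in one of them and without one in the other: 1 of 4 stereo elements differ; a stereocentre at a saturated ring carbon is drawn R in compound 1 and S in compound 4. Within the data shown here, no pairwise step exists among the measured compounds that would show how such an inversion moves this assay, and no step between measured compounds is available at all. The expectation is that any step from compound 1 to compound 4 in this assay is none beyond the scatter, so that compound 4 most probably remains at or near the floor, with a real chance that it too is reported without a number. On that basis compound 4 is estimated at 0.03, with a range from 0 to 0.15.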

Compound 4, intrinsic activity: the largest response reached, as a fraction of the reference agonist's: "not active" (no number reported)
Compound 4 has no reported number here, so the estimate cannot be set against anything.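

In this assay, compound 1 and compound 4 are both reported without a number, so no step can be read between them. It remains open whether inverting the stereocentre at this saturated ring carbon changes the maximal response at all, and the only recorded point on the pair is: the fact that one of compounds 1 and 4 is drawn with a defined configuration and the other without, at the place where they differ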